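Moving from a Thioether to an Ether on the Side Chain

The source may hold more compounds than are shown below. What is called first, only, known or untested is meant among the compounds shown, and "the series" means these compounds.

Compound 2 `CCOC(=O)/C=C(C)/C=C/CC(C)CCCC(C)CC` stands highest of the two compounds measured in a physicochemical assay for lipophilicity (on this read-out higher numbers stand for higher lipophilicity and lower numbers for lower lipophilicity), giving 7.81. Its nearest neighbour, compound 1 `CCOC(=O)/C=C(C)/C=C/CC(C)CCCC(C)(C)SC`, gives 6.36 in this assay. Among the compounds with values here, the one measured step between them, a number 1.45 log units higher from compound 1 to compound 2 (beyond the scatter), shows how strongly this read-out answers when a sulfur-bearing group is exchanged for an all-carbon group on the saturated part of the chain.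

Compound 3 `CCOC(=O)/C=C(C)/C=C/CC(C)CCC(OC)C(C)C` differs from compound 2 in that same region: 1-methoxy-2-methylpropyl in place of 2-methylbutyl on a saturated chain carbon, four bonds along the chain from a double-bonded chain carbon. The change now runs in the opposite sense to the measured step, introducing an oxygen and one hydrogen-bond acceptor where compound 2 carries only carbon. On the strength of the step from compound 1 to compound 2, a decrease beyond the scatter is expected for compound 3, though probably smaller, at about a number 1.01 log units lower from compound 2 to compound 3 (beyond the scatter). Compound 3 is therefore estimated at 6.8, in the range 6.2 to 7.4.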

Compound 3, partition coefficient: 5.54
Beside the measured number, compound 3's estimate is 1.26 log units above it; the measured number lies below the stated range.
By their numbers in this assay, from the lowest: compound 3; then compound 1; then compound 2.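

In this assay, 1-methoxy-2-methylpropyl in place of 2-methylbutyl, on a saturated chain carbon four bonds along the chain from a double-bonded chain carbon, gives a number 2.27 log units lower from compound 2 to compound 3 (beyond the scatter), so this part of the chain answers to an oxygen-bearing group as well as to a sulfur-bearing one. The ether also does not land near the thioether: 1-methoxy-2-methylpropyl in place of 2-methyl-2-(methylsulfanyl)propyl gives a number 0.82 log units lower from compound 1 to compound 3 (beyond the scatter), which leaves the methoxy-bearing group with the lowest number of the three. Nothing available explains why the read-out falls this far.

The exchange alters the branching of the chain together with the added oxygen, and the compounds shown do not separate the two. As far as these compounds go, how a hydroxyl, an amine or a longer alkoxy chain would read at this place remains open.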